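A few compounds are considered here, and "the series" means these few. Any claim that something is new, unique, unknown or untested is made for them only; others in the source may bear on it.

Measured so far:
- compound 1, `COc1ccc(-c2cs/c(=N/NC(=O)CSc3nnnn3-c3ccccc3)n2-c2ccccc2)cc1`, gives 11.7 ug/mL in an ADME assay on NIH3T3 cells (Mus musculus) for cytotoxicity, read by MTT assay, with a stated time of 24 h; a higher number here means a weaker inhibitor, a lower number a stronger inhibitor
- compound 2, `Cn1nnnc1SCC(=O)N/N=c1/scc(-c2ccc(F)cc2)n1-c1ccccc1`, gives 113 ug/mL in this assay

Compound 2 stands at the higher of the two numbers, meaning it is the weaker inhibitor of the two; compound 1 sits well away from it, beyond the scatter of the method. The two compounds differ in more than one place, so their values show only that the two structures sit far apart on this scale.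

Compound 3, `O=C(CSc1nnnn1-c1ccccc1)N/N=c1/scc(-c2ccc(F)cc2)n1-c1ccccc1`, has not been measured. It is made from compound 2 by one change: phenyl in place of methyl on an aromatic nitrogen. The compound that results carries the same phenyl-bearing tetrazole as compound 1.

Going by the values given here, no measured pair shows this change alone, so the size of the step is uncertain. A downward step from compound 2 to compound 3 is expected, a 3.8-fold lower number from compound 2 to compound 3 (0.58 log units; beyond the scatter), because compound 1, which also carries the phenyl on that ring nitrogen, gives 11.7 ug/mL. Compound 3 is therefore estimated at 30 ug/mL, with a range from 9 ug/mL to 110 ug/mL.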

Compound 3, half-maximal inhibitory concentration: 207 ug/mL
Compound 3: middle estimate off by 6.9-fold (0.84 log units), on the low side; measured number outside the range, above it.
By their numbers in this assay, from the lowest: compound 1; then compounds 2 and 3 (each within the scatter of the next).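

In this assay the change from 1-methyl-1H-tetrazol-5-yl to 1-phenyl-1H-tetrazol-5-yl, a phenyl in place of methyl on the aromatic nitrogen, gives a 1.8-fold higher number from compound 2 to compound 3 (0.26 log units; within the scatter) and so cannot be told apart from repeat measurement; in this pair, a much larger group on that nitrogen leaves the reading effectively unchanged. The large gap appears instead at the other place, where fluoro in place of methoxy on an aromatic carbon gives an 18-fold higher number from compound 1 to compound 3 (1.25 log units; beyond the scatter) with the phenyl-bearing tetrazole held constant, so the far lower number of compound 1 goes with its methoxy and not with the phenyl it shares with compound 3. Nothing measured here gives a reason for either step.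

The compounds shown leave open whether methoxy in place of fluoro would produce a similar step when the tetrazole nitrogen carries methyl, since this step has been read only with phenyl there. They also leave open how an ethyl or a benzyl on that nitrogen, or a chloro or a hydroxyl in place of the fluoro, would read in this assay.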